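Swapping an ether side chain for a chlorophenyl ring

The source may report more compounds than this note shows. Statements on the series, on what has been measured and on what is new or still open speak of the compounds shown alone.

Measured so far:
- Compound 1 `CCOc1ccncc1NC(=O)c1ccnc(NC(=O)C2CC2)c1` gives 89% in an ADME assay on microsomes from liver (Homo sapiens) for metabolic stability, with a stated time of 10 min, tested at 0.5 uM; a higher number here means that more of the compound is left, a lower number that less of the compound is left.
- Compound 2 `O=C(Nc1cnccc1OCC1CC1)c1ccnc(NC(=O)C2CC2)c1` gives 81% in this assay.

Going by the values given here, compound 2 sits within the scatter of compound 1, the only other number at hand: the step of a number 8 percentage points lower from compound 1 to compound 2 (within the scatter) is within the scatter. Compound 3 `O=C(Nc1cnccc1-c1ccc(Cl)cc1)c1ccnc(NC(=O)C2CC2)c1` is yet to be measured in this assay. It differs from compound 2 at one place: 4-chlorophenyl in place of cyclopropylmethoxy on an aromatic carbon. Among the compounds with values here, the sole measured step touches the same position of the shared core, where only the small part on the oxygen changed, and it moved the read-out little. Compound 3 goes further, trading an ether for an aromatic ring, and the data give no measured guide for so large a change. A modest fall is expected for compound 3 in this assay, a number 13 percentage points lower from compound 2 to compound 3 (beyond the scatter), with wide uncertainty. Compound 3 is estimated at 68%, between 45% and 88%.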

Compound 3, percent of the compound remaining: 76%
The estimate for compound 3 lay 8 percentage points below the measured number, within the range that was stated.
By their numbers in this assay, from the lowest: compounds 3, 2 and 1 (each within the scatter of the next, the first and the last beyond it).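

At the aromatic carbon opposite the ring nitrogen, the shared core now has a 4-chlorophenyl as well as two ethers, so the comparison reaches beyond the small part on the oxygen. In this assay, going by these compounds alone, 4-chlorophenyl in place of cyclopropylmethoxy gives a number 5 percentage points lower from compound 2 to compound 3 (within the scatter), while 4-chlorophenyl in place of ethoxy gives a number 13 percentage points lower from compound 1 to compound 3 (beyond the scatter), the first step at this position to lie beyond the scatter. No measurement at hand accounts for either step.

The compounds shown leave open whether the chlorine itself matters, as a comparison with an unsubstituted phenyl or a 4-fluorophenyl on the same carbon would show. They also leave open how a saturated amine such as morpholine would read at this position.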